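This account rests on a few compounds, and the source may have more. Where it says the series, first, only, none or still open, it means among the compounds named here.

In an assay for binding affinity to 17-beta-hydroxysteroid dehydrogenase type 2 (Homo sapiens), with a stated time of 20 min, tested at 1 uM (on this read-out higher numbers stand for more inhibition at the one concentration tested (going by the name of the read-out) and lower numbers for less inhibition), compound 2 `Oc1cccc(-c2ccc3c(O)cccc3c2)c1` gives 32%, the highest of the two numbers reported. For the measured compounds named here, its nearest neighbour is compound 1 `Oc1cccc(-c2ccc3ccccc3c2)c1`, which gives 12%; the only measured step, a number 20 percentage points higher from compound 1 to compound 2 (beyond the scatter), lies beyond the scatter. Compound 3 `Oc1cccc2cc(-c3cncnc3)ccc12` gives only a limit in this assay, < 10%, and the limit of < 10% in this assay, at which 1 of the 3 values shown sits, is the only such limit in the set. Compound 4 `CNC(=O)c1cccc(-c2ccc3c(O)cccc3c2)c1` differs from compound 2 by methylcarbamoyl in place of hydroxy on an aromatic carbon. Going by the values given here, the measured step concerns a hydroxy entering at a different place, so it bears only loosely on this change, and no measured step covers methylcarbamoyl. Compound 4 is therefore expected to move by a number 7 percentage points lower from compound 2 to compound 4 (within the scatter) in this assay, with an estimated 25% between 5% and 50%.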

Compound 4, a percentage reported as inhibition, at one concentration (the size of the read-out at that concentration, not a potency): 43%
Compound 4: the middle estimate sits 18 percentage points below what was measured, and the stated range covers the measured number.
By their numbers in this assay, from the lowest: compound 1; then compound 2; then compound 4. At a limit, below all of these: compound 3.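

Replacing hydroxy with methylcarbamoyl at this place, meta to a large group, gives a number 11 percentage points higher from compound 2 to compound 4 (beyond the scatter), so in this assay the hydroxy here can be exchanged without loss of inhibition. The earlier step concerned a hydroxy entering elsewhere on the core, whereas this one shows that a larger group is accepted at this position. Nothing among the data shown accounts for the rise. Going by these compounds, whether it comes from the carbonyl, the amide hydrogen or the methyl stays open. On these data alone, how a carboxylic acid or an amine would read at this place also remains open.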